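The source may report more compounds than this note shows. Statements on the series, on what has been measured and on what is new or still open speak of the compounds shown alone.

Compound 1 (`O=C(NCc1ccc(S(=O)(=O)c2ccccc2)cc1)c1nc2cnccc2[nH]1`) 7.3%
Compound 2 (`O=C(NCc1ccc(S(=O)(=O)c2ccccc2)cc1)c1cc2ncccc2s1`) 1.6%

In an ADME assay on microsomes from liver (Mus musculus) for metabolic stability, read by LC-MS, with a stated time of 30 min, tested at 1 uM (a higher number here means that more of the compound is left, a lower number that less of the compound is left), compound 2 gives 1.6% and compound 1 gives 7.3%, two values within the scatter of each other. Compound 3 (`O=C(NCc1ccc(S(=O)(=O)c2ccccc2)cc1)c1nc2ccncc2s1`) differs from compound 2 on a carbonyl carbon: a group of 9 heavy atoms (6 carbon, 2 nitrogen, 1 sulfur; one five-membered aromatic ring with 2 hetero atoms, one six-membered aromatic ring with 1 hetero atom) in place of a group of 9 heavy atoms (7 carbon, 1 nitrogen, 1 sulfur; one five-membered aromatic ring with 1 hetero atom, one six-membered aromatic ring with 1 hetero atom), on a carbonyl carbon. Within the data shown here, the one measured step that bears on this, a similar exchange on that carbonyl carbon, is (a number 5.7 percentage points lower from compound 1 to compound 2 (within the scatter)). No step beyond the scatter is therefore expected in this assay, in either direction. The expected step is (a number 3.4 percentage points higher from compound 2 to compound 3 (within the scatter)). Compound 3 is estimated at 5%, with an expected range from 1% to 15%.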

Compound 3, percent of the compound remaining: 26%
Compound 3: middle estimate off by 21 percentage points, on the low side; measured number above the stated range.
By their numbers in this assay, from the lowest: compounds 2 and 1 (each within the scatter of the next); then compound 3.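

At this carbonyl carbon, this assay now records a number 24.4 percentage points higher from compound 2 to compound 3 (beyond the scatter) and also a number 18.7 percentage points higher from compound 1 to compound 3 (beyond the scatter) so an exchange here can move the number beyond the scatter, which the earlier pair did not show. The groups of compound 1 and compound 3 have the same ring description, with two hetero atoms in the five-membered ring and one in the six-membered ring, yet their numbers still differ beyond the scatter. Nothing at hand explains these steps.

Going by these compounds, it remains open whether the higher number holds with a methoxy group or a fluorine atom on the group at this carbonyl carbon. The compounds shown also leave open whether it holds with an amine there.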